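Changing the amide side group of compound 3

This account rests on a few compounds, and the source may have more. Where it says the series, first, only, none or still open, it means among the compounds named here.

In a physicochemical assay for solubility, read by spectrophotometry, measured as kinetic solubility, at pH 8, tested at 500 uM (on this read-out higher numbers stand for higher solubility and lower numbers for lower solubility), compound 1 (`CN(C)C(=O)c1ccncc1Nc1cc(-c2ccc3ccn(C)c3c2)c2nccnc2c1`) gives 175 ug/mL while compound 2 (`Cn1ccc2ccc(-c3cc(Nc4cnccc4C(=O)NCc4cncnc4)cc4nccnc34)cc21`) gives 233 ug/mL and compound 3 (`CC(=O)N1CCC(NC(=O)c2ccncc2Nc2cc(-c3ccc4ccn(C)c4c3)c3nccnc3c2)CC1`) gives 213 ug/mL as its reading. Compound 3 therefore sits within the scatter of both other compounds. Compound 4 (`Cn1ccc2ccc(-c3cc(Nc4cnccc4C(=O)NCC4COCCN4)cc4nccnc34)cc21`) keeps the shared core and differs from compound 3 only on an amide-type nitrogen, where (morpholin-3-yl)methyl stands in place of 1-acetylpiperidin-4-yl ((morpholin-3-yl)methyl in place of 1-acetylpiperidin-4-yl on an amide-type nitrogen). Three measured steps swap groups at this same place. They are a 1.3-fold higher number from compound 1 to compound 2 (0.12 log units; within the scatter) and a 1.2-fold higher number from compound 1 to compound 3 (0.09 log units; within the scatter) and a 1.1-fold lower number from compound 2 to compound 3 (0.04 log units; within the scatter) and all three lie within the scatter. As far as these compounds go, none of them brings in the (morpholin-3-yl)methyl group, so the new group itself remains untested. Resting on those three small steps, the expected step is a 1.0-fold higher number from compound 3 to compound 4 (0.00 log units; within the scatter) in this assay and nothing beyond the scatter is expected. For compound 4 the estimated value is 215 ug/mL with an expected range from 145 ug/mL to 270 ug/mL in this measurement.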

Compound 4, solubility: 239 ug/mL
Beside the measured number, compound 4's estimate is 1.1-fold (0.05 log units) below it, within the range that was stated.
By their numbers in this assay, from the lowest: compounds 1, 3, 2 and 4 (each within the scatter of the next).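

Among the compounds shown here, the (morpholin-3-yl)methyl group, whose ring has 2 hetero atoms and which brings 1 hydrogen-bond donor, is the first group at this place with a ring of that kind, and in this assay all three new steps are small: a 1.1-fold higher number from compound 3 to compound 4 (0.05 log units; within the scatter), a 1.0-fold higher number from compound 2 to compound 4 (0.01 log units; within the scatter) and a 1.4-fold higher number from compound 1 to compound 4 (0.14 log units; within the scatter). With this result, all four amide side groups shown lie within the scatter of one another, so this read-out does not separate them, even though their rings and hydrogen-bond counts differ. No separate measurement is available to explain why these readings stay together.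

The compounds shown leave open whether a side group carrying a carboxylic acid, or a longer chain ending in a primary amine, would give a step beyond the scatter at this amide-type nitrogen. They also leave open whether these four side groups would stay together on any other read-out.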